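Thiazole alkyne to nitrile: working notes on cytotoxicity

The source may hold more compounds than are shown below. What is called first, only, known or untested is meant among the compounds shown, and "the series" means these compounds.

Compound 1 `C#Cc1nc2ccccc2s1`: 19600 nM
Compound 2 `C#Cc1nccs1`: > 40000 nM (a limit of the assay)

All values come from a functional assay on HCT-116 cells (Homo sapiens) for cytotoxicity, with a stated time of 3 days; a lower number here means a stronger inhibitor, a higher number a weaker inhibitor. Compound 1 gives a numerical reading of 19600 nM. Compound 2 reads > 40000 nM, which is a limit of the assay and not a number. Compound 2 therefore has no exact position on the scale, only the limit: the limit of > 40000 nM in this assay, at which 1 of the 2 values shown sits.

The next entry is compound 3 `N#Cc1nccs1`, with the change (cyano in place of ethynyl on an aromatic carbon). In words, this is cyano in place of ethynyl on an aromatic carbon, next to the ring nitrogen and next to the ring sulfur.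

Among the compounds with values here, no measured step covers this exchange. The expectation therefore rests on compound 2 alone, with its limit of > 40000 nM. No change beyond the usual scatter is expected in this assay, and a second limit reading is quite likely. The expected size of the change is a step that the limit leaves unreadable from compound 2 to compound 3. For compound 3 the estimated value is 50000 nM, with an expected range of 25000 nM to 100000 nM.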

Compound 3, half-maximal inhibitory concentration: > 40000 nM
Compound 3 gave a limit, no number (the forecaster's own chance of this, stated with the estimate: 70%); the middle value is on the limit's open side.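

Compound 2 and compound 3 each give a limit of the assay and not a number, so no step can be read between them. The compounds shown leave open how far either lies past that limit, and whether cyano in place of ethynyl changes the reading at all: the limit of > 40000 nM in this assay, at which 2 of the 3 values shown sit.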